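A few compounds are considered here, and "the series" means these few. Any claim that something is new, unique, unknown or untested is made for them only; others in the source may bear on it.

Compound 3 `CC(C)C[C@H](NC(=O)CN(c1ncnc2c1ncn2C1CCCCO1)C1CC1)C(=O)OCc1ccccc1` and compound 1 `NC(=O)C[C@H](NC(=O)CN(c1ncnc2c1ncn2C1CCCCO1)C1CC1)C(=O)OCc1ccccc1` share one core and differ in a single spot: carbamoyl in place of isopropyl on a saturated chain carbon, two bonds along the chain from an amide-type nitrogen and a carbonyl carbon. In a functional assay on the whole organism (Tail, strain ICR) with Mus musculus as the target, in the tail flick test, with a stated time of 150 min, at a dose of 25 umol/kg by the oral route (on this read-out lower numbers stand for a weaker effect and higher numbers for a stronger effect at the one dose given), compound 3 gives 6.47%, while compound 1 gives 21.7%. Compound 2 `CC(C)C[C@H](NC(=O)CN(c1nc(Cl)nc2[nH]cnc12)C1CC1)C(=O)OCc1ccccc1` is built on a different core; how that core differs from the core of compound 3 is not broken down here. In this assay compound 2 gives 5.26%. Compound 4 `NC(=O)C[C@H](NC(=O)CN(c1nc(Cl)nc2[nH]cnc12)C1CC1)C(=O)OCc1ccccc1` has not yet been measured, and it is reached from compound 2 by the same change, (carbamoyl in place of isopropyl on a saturated chain carbon, two bonds along the chain from an amide-type nitrogen and a carbonyl carbon). Because the earlier step was a number 15.2 percentage points higher from compound 3 to compound 1 (beyond the scatter), a step of about a number 13.7 percentage points higher from compound 2 to compound 4 (beyond the scatter) is expected in this assay for the new pair, resting on that single precedent. Compound 4 is therefore estimated at 19%, most likely between 7% and 31%.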

Compound 4, a percentage reported as activity, at one dose (the size of the read-out at that dose, not a potency): 13.5%
For compound 4 the middle estimate is 5.5 percentage points above the measured one; the measured number falls inside the stated range.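

In this assay carbamoyl in place of isopropyl on the second core gives a number 8.2 percentage points higher from compound 2 to compound 4 (within the scatter) and the two cores can then be compared: the same change on two cores in this assay, a number 15.2 percentage points higher (beyond the scatter) from compound 3 to compound 1 and a number 8.2 percentage points higher (within the scatter) from compound 2 to compound 4, 7 percentage points apart, within the scatter of two such steps. So the change carries over from one core to the other with no detectable difference in the size of the step. It does not show a firm gain on the second core, where the step alone stays inside the scatter, and two pairs at a single dose and a single time cannot establish a rule for the series.

The compounds shown leave open whether another group at this place, such as an amine, a carboxylic acid or a longer chain, would give a step of similar size. They also leave open how this change behaves on any further core.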